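Removing a Methoxy From a Compound at the Assay Limit

The source may report more compounds than this note shows. Statements on the series, on what has been measured and on what is new or still open speak of the compounds shown alone.

In a functional assay on HeLa cells (Homo sapiens) for antiproliferative activity, read by cell counting, with a stated time of 2 days (on this read-out higher numbers stand for weaker inhibition and lower numbers for stronger inhibition), compound 1 `COc1ccc(Nc2nc(N)c(C(=O)c3ccccc3)s2)cc1` gives 230 nM and compound 2 `COc1cc(C(=O)c2sc(Nc3ccc(F)cc3)nc2N)cc(OC)c1OC` gives 440 nM, two values within the usual scatter of each other. Compound 3 `COc1ccc(C(=O)c2sc(Nc3ccc(Cl)cc3)nc2N)cc1` gives only a limit, > 10000 nM, and not a number.

Compound 4 `Nc1nc(Nc2ccc(Cl)cc2)sc1C(=O)c1ccccc1` differs from compound 3 in one place: hydrogen in place of methoxy on an aromatic carbon, para to a large group, so that 4-methoxyphenyl becomes phenyl (hydrogen in place of methoxy on an aromatic carbon). For the measured compounds named here, no measured pair shows this change alone, so the evidence is thin. Compound 1 also carries a phenyl on its carbonyl, and compound 1 gives 230 nM. A move toward stronger inhibition, meaning a lower number in this assay, is therefore expected, probably beyond the usual scatter, but its true size cannot be fixed while compound 3 has no number. The expected step of an at least 6.6-fold lower number from compound 3 to compound 4 (0.82 log units; beyond the scatter) is only an estimate. For compound 4 the estimated value is 1500 nM, with an expected range from 150 nM to 10000 nM.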

Compound 4, half-maximal inhibitory concentration: > 10000 nM
Compound 4: only a limit was reported; the forecaster's own chance of this, stated with the estimate: 25%; at least 6.6-fold (0.82 log units) between middle value and limit.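

Removing the methoxy from the 4-methoxyphenyl of compound 3 does not bring the series back into measurable range: in this assay, compound 4 gives > 10000 nM, which is a limit and not a number. The step between these two compounds cannot be read, because both stop at the same limit: the limit of > 10000 nM in this assay, at which 2 of the 4 values shown sit.

The new information comes from the other comparison, which shows that a phenyl on the carbonyl is not enough on its own, as chloro in place of methoxy on an aromatic carbon gives an at least 43-fold higher number from compound 1 to compound 4 (1.63 log units; beyond the scatter). On these data alone, whether a smaller swap at that carbon, such as methyl or hydroxyl in place of chloro, would keep a measurable value remains open, since this rests on one pair. As far as these compounds go, what the methoxy of compound 3 contributes also remains unknown.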